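Permeability notes: sulfonyl-for-carbamoyl swap on the piperidine nitrogen

A few compounds are considered here, and "the series" means these few. Any claim that something is new, unique, unknown or untested is made for them only; others in the source may bear on it.

Compound 1 `CC(C)NC(=O)N1CCC(CN(C2Cc3cc(C#N)ccc3N(Cc3cncn3C)C2)S(=O)(=O)c2ccccn2)CC1` gives 0.6 10^-6 cm/s in an ADME assay on Caco-2 cells (Homo sapiens) for permeability, in the apical to basolateral direction (on this read-out higher numbers stand for higher permeability and lower numbers for lower permeability), which places it second highest among the three measured compounds. Compound 3 `CCOC(=O)N1CCC(CN(C2Cc3cc(C#N)ccc3N(Cc3cncn3C)C2)S(=O)(=O)c2ccccn2)CC1` gives 2.6 10^-6 cm/s and the step of a 4.3-fold higher number from compound 1 to compound 3 (0.64 log units; beyond the scatter) is modest; compound 2 `Cn1cnc(S(=O)(=O)N(Cc2cccc(-n3cccc3)c2)C2Cc3cc(C#N)ccc3N(Cc3cncn3C)C2)c1` gives 0.2 10^-6 cm/s, a lower number than compound 1 by more than the scatter.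

Compound 4 `Cn1cnc(S(=O)(=O)N2CCC(CN(C3Cc4cc(C#N)ccc4N(Cc4cncn4C)C3)S(=O)(=O)c3ccccn3)CC2)c1` is unmeasured. It differs from compound 1 by (1-methyl-1H-imidazol-4-yl)sulfonyl in place of isopropylcarbamoyl on an amine nitrogen in a ring, on an amine nitrogen in a ring of a six-membered non-aromatic ring with 1 nitrogen. The leaving group has 1 hydrogen-bond donor; the entering group has 0 hydrogen-bond donors and 4 hydrogen-bond acceptors.

Among the compounds with values here, only the step from compound 1 to compound 3 touches the same amine nitrogen, and it replaced a different part of the group, so no measured step bears directly on this change. Compound 2, which carries the same entering group at another place, shows the lowest value; this is only a value, not a step. Compound 4 is therefore expected to give 0.5 10^-6 cm/s, within 0.15 10^-6 cm/s to 1.5 10^-6 cm/s, a step of a 1.2-fold lower number from compound 1 to compound 4 (0.08 log units; within the scatter) that is estimated to be within or near the scatter.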

Compound 4, apparent permeability: 0.1 10^-6 cm/s
The estimate for compound 4 lay 5.0-fold (0.70 log units) above the measured number, outside the stated range (below it).
By their numbers in this assay, from the lowest: compounds 4 and 2 (each within the scatter of the next); then compound 1; then compound 3.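

At the amine nitrogen in the six-membered non-aromatic ring, the whole group can be replaced with a clear consequence in this assay: (1-methyl-1H-imidazol-4-yl)sulfonyl gives a 6.0-fold lower number from compound 1 to compound 4 (0.78 log units; beyond the scatter) in place of isopropylcarbamoyl and a 26-fold lower number from compound 3 to compound 4 (1.41 log units; beyond the scatter) in place of ethoxycarbonyl, both beyond the scatter. The change to compound 4 removes the hydrogen-bond donor of isopropylcarbamoyl, as did the earlier change with a 4.3-fold higher number from compound 1 to compound 3 (0.64 log units; beyond the scatter) on the same group, yet the two steps run in opposite directions, so the donor count of this group does not alone set the number in these compounds. No measurement is available that explains either step.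

Still open, from the compounds shown here alone, is whether the lower number goes with the sulfonyl link or with the five-membered aromatic ring it carries; methanesulfonyl or benzenesulfonyl on the same nitrogen would separate the two. Also open, going by these compounds, is how a carbamate with a longer chain than ethoxy would read.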